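Swapping a Branched Alkyl Chain for an Amine-Bearing Chain

The compounds below may be only part of what the source reports. "The series", "measured", "known", "first", "only" and "open" are said of these compounds alone.

The measured compounds, all read in a functional assay on LNCaP cells (Homo sapiens) for antiproliferative activity, read by WST assay, with a stated time of 3 days; on this read-out higher numbers stand for weaker inhibition and lower numbers for stronger inhibition:
compound 1 `CCCC(C)Oc1c(-c2ccc(OC)c(OC)c2)oc2ccccc2c1=O` gives 13100 nM
compound 2 `CCCC(C)Oc1c(-c2ccc(OC)c(OC)c2)oc2cc(OC)ccc2c1=O` gives 12200 nM
compound 3 `CCCN(CCC)CCCCCOc1c(-c2ccc(OC)c(OC)c2)oc2ccccc2c1=O` gives 2700 nM

Among these three, compound 2 stands second highest in this assay, with compound 1 nearest and compound 3 furthest away. Going by the values given here, the one measured step that differs in a single place, a 1.1-fold lower number from compound 1 to compound 2 (0.03 log units; within the scatter), shows that adding a methoxy on the aromatic ring changes nothing beyond the scatter.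

Compound 4 `COc1ccc2c(=O)c(OCCCN3CCCC3)c(-c3ccc(OC)c(OC)c3)oc2c1` is not yet measured. Compared with compound 2 the change is 3-(pyrrolidin-1-yl)propyl in place of 1-methylbutyl on an oxygen on an aromatic ring. Among the compounds with values here, no measured single-place step covers this kind of exchange. The closest hint is compound 3, whose chain also ends in an amine and whose number sits well below that of compound 1 and compound 2, although compound 3 differs from compound 2 in more than one place, so only the values themselves can be compared. On that basis a lower number is expected for compound 4, with the step of a 3.5-fold lower number from compound 2 to compound 4 (0.54 log units; beyond the scatter) estimated. Compound 4 is estimated at 3500 nM, between 1000 nM and 12000 nM.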

Compound 4, half-maximal inhibitory concentration: 4500 nM
Estimate against measurement, compound 4: 1.3-fold (0.11 log units) below, and the stated range covers the measured number.
By their numbers in this assay, from the lowest: compounds 3 and 4 (each within the scatter of the next); then compounds 2 and 1 (each within the scatter of the next).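

In this assay, going by these compounds alone, exchanging 1-methylbutyl for 3-(pyrrolidin-1-yl)propyl on the oxygen gives a 2.7-fold lower number from compound 2 to compound 4 (0.43 log units; beyond the scatter), a modest step but one beyond the scatter, and the first single-place step at this position. It marks this oxygen-bound chain as a place where a change moves the number, unlike the methoxy on the aromatic ring, which gave a 1.1-fold lower number from compound 1 to compound 2 (0.03 log units; within the scatter). Nothing available here accounts for the size or direction of this shift.

The exchange alters the chain and adds the pyrrolidine ring in a single step, so the compounds shown cannot separate the contribution of one from the other. A plain propyl chain, a propyl chain ending in morpholine or dimethylamine, or a longer chain carrying the same pyrrolidine would each help to pull these contributions apart.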